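Swapping methyl for trifluoromethyl on the dichlorophenyl ketone

The compounds below may be only part of what the source reports. "The series", "measured", "known", "first", "only" and "open" are said of these compounds alone.

Compound 2 `Cc1cccc(Cl)c1C(=O)c1cn(-c2ccc(C(=O)O)cc2F)c2ncccc12` is the weaker of the two measured compounds in an ADME assay on microsomes from liver (Homo sapiens) for metabolic stability, read by LC-MS, using NADPH, with stated times of 5 min and 30 min, tested at 1 uM (on this read-out lower numbers stand for a less stable compound and higher numbers for a more stable compound), where compound 2 gives 88% against 100% for compound 1 `O=C(O)c1ccc(-n2cc(C(=O)c3c(Cl)cccc3Cl)c3cccnc32)c(F)c1`. Going by the values given here, the one measured step, a number 12 percentage points lower from compound 1 to compound 2 (beyond the scatter), came from putting methyl in place of chloro. Compound 3 `O=C(O)c1ccc(-n2cc(C(=O)c3c(Cl)cccc3C(F)(F)F)c3cccnc32)c(F)c1` now undoes that methyl: trifluoromethyl in place of methyl on an aromatic carbon. Among the compounds with values here, no measured step pairs trifluoromethyl with methyl, so the only guide is that the methyl cost compound 2 a modest amount; a step back upward is therefore expected, a number 6 percentage points higher from compound 2 to compound 3 (within the scatter), with compound 3 estimated at 94% within 80% to 100%.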

Compound 3, percent of the compound remaining: 100%
Estimate against measurement, compound 3: 6 percentage points below, within the range that was stated.
By their numbers in this assay, from the lowest: compound 2; then compounds 1 and 3 (each within the scatter of the next).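

Trifluoromethyl in place of methyl on this aromatic carbon gives a number 12 percentage points higher from compound 2 to compound 3 (beyond the scatter) in this assay and trifluoromethyl in place of chloro gives no change at the digits printed from compound 1 to compound 3 (within the scatter). Of the three groups seen at this position, methyl alone stands apart, while chloro and trifluoromethyl cannot be told apart on this read-out. Nothing available here explains why these groups differ. On these data alone, whether an amine, a methoxy group or a longer chain at this position would match chloro and trifluoromethyl or fall with methyl stays open.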